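Replacing a Fluorophenyl Tail with a Dibromohydroxyphenyl

This account rests on a few compounds, and the source may have more. Where it says the series, first, only, none or still open, it means among the compounds named here.

Measured compounds:
Compound 1 `O=C(N/N=C/c1ccc(F)cc1)Nc1cc2c(Nc3ccc(F)c(Cl)c3)ncnc2cc1O[C@H]1CCOC1` gave "not active" (no number reported) in a functional assay on HepG2 cells (Homo sapiens) for cytotoxicity, read by MTT assay, with a stated time of 72 h; a lower number here means a stronger inhibitor, a higher number a weaker inhibitor.
Compound 2 `COc1ccc(/C=N/NC(=O)Nc2cc3c(Nc4ccc(F)c(Cl)c4)ncnc3cc2O[C@H]2CCOC2)cc1` gave 28800 nM in this assay.

Compound 1 stands without a single number in this assay: it was recorded as inactive, so it cannot be placed on the same scale as compound 2, which shows only weak inhibition at 28800 nM. Compound 3 `O=C(N/N=C/c1cc(Br)c(O)c(Br)c1)Nc1cc2c(Nc3ccc(F)c(Cl)c3)ncnc2cc1O[C@H]1CCOC1` has not yet been tested. It differs from compound 1 by 3,5-dibromo-4-hydroxyphenyl in place of 4-fluorophenyl on a carbon with a double bond to nitrogen. Among the measured compounds shown here, no measured step between two compounds isolates this change, so its size cannot be read from the data. Since compound 1 gave "not active" (no number reported) and compound 2 reached only 28800 nM, compound 3 is expected to remain weak in this assay, with a real chance that again no number is reported. Compound 3 is estimated at about 30000 nM in this assay, within 8000 nM to 100000 nM.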

Compound 3, half-maximal inhibitory concentration: 2740 nM
Estimate against measurement, compound 3: 11-fold (1.04 log units) above, and the stated range ends above it.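

In this assay the group on the carbon with a double bond to nitrogen has a strong say in the read-out: 3,5-dibromo-4-hydroxyphenyl in place of 4-methoxyphenyl gives an 11-fold lower number from compound 2 to compound 3 (1.02 log units; beyond the scatter) and moves the number well beyond the usual scatter. Compound 3 also carries a real number where compound 1 has none, so this position can take the series from no reported number to a clearly lower one. Nothing available here explains why this change acts as it does.

The compounds shown change the two bromines and the hydroxyl together, so it stays open which of them matters; a plain 4-hydroxyphenyl or a 3,5-dibromophenyl would separate them. Also open, from the compounds shown here alone, is how a quite different group here, such as an amine or a carboxylic acid, would behave.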